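Removing the Hydroxymethyl from a Sugar Thiosemicarbazide

This account rests on a few compounds, and the source may have more. Where it says the series, first, only, none or still open, it means among the compounds named here.

Compound 1 `CC(=O)O[C@@H]1[C@@H](OC(C)=O)[C@H](O)[C@@H](CO)O[C@H]1NC(=S)NNC(=O)Cn1cnc2c(N)ncnc21` is reported in a functional assay on Bel-7402 cells (Homo sapiens) for cytotoxicity, read by MTT assay, with a stated time of 48 h (on this read-out lower numbers stand for an effect already at smaller amounts and higher numbers for an effect only at larger amounts of compound), only as a limit of the assay, >= 200000 nM. Compound 2 `CC(=O)O[C@@H]1[C@@H](OC(C)=O)[C@@H](O)[C@@H](CO)O[C@H]1NC(=S)NNC(=O)Cn1cnc2c(N)ncnc21` gives 86200 nM in this assay.

Among the compounds with values here, the two compounds carry the same atoms and bonds and differ only in configuration as drawn (the fact that compounds 1 and 2 differ only in the configuration as drawn); the step of an at least 2.3-fold lower number from compound 1 to compound 2 (0.36 log units; beyond the scatter) is the only measured step. Compound 2 thus holds the only number shown, the other value being a limit (the limit of >= 200000 nM in this assay, at which 1 of the 2 values shown sits).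

Compound 3 `CC(=O)O[C@@H]1[C@@H](OC(C)=O)[C@@H](O)CO[C@H]1NC(=S)NNC(=O)Cn1cnc2c(N)ncnc21` differs from compound 2 by hydrogen in place of hydroxymethyl on a saturated ring carbon. Within the data shown here, no measured step bears on this change: the single step available turns on configuration alone and says nothing about the loss of a group. Compound 3 is therefore expected to give about 100000 nM in this assay, somewhere between 40000 nM and 250000 nM. The step of a 1.2-fold higher number from compound 2 to compound 3 (0.06 log units; within the scatter) is expected to remain within the usual scatter, with a real chance that only a limit is reported.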

Compound 3, half-maximal effective concentration: > 100000 nM
Compound 3: a limit, no number; the forecaster's own chance of this, stated with the estimate: 30%; the middle value sits exactly at the limit.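

In this assay compound 3 gives only a limit, > 100000 nM. Hydrogen in place of hydroxymethyl on a saturated ring carbon gives an at least 1.1-fold higher number from compound 2 to compound 3 (0.06 log units; that floor lies within the scatter), so this change brings no lower number, which the earlier step on configuration alone could not show. Whether the number truly rises beyond the scatter, and by how much, cannot be read because the new value is a limit: the limit of > 100000 nM in this assay, at which 1 of the 3 values shown sits.

The compounds shown leave open how an amine, a carboxylic acid or a longer chain such as hydroxyethyl on this ring carbon would read in this assay. They also leave open whether the configuration step an at least 2.3-fold lower number from compound 1 to compound 2 (0.36 log units; beyond the scatter) would carry over to a compound that has hydrogen in place of hydroxymethyl.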